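Pentyl on Selenium: Expected Cost to Growth Inhibition

The source may hold more compounds than are shown below. What is called first, only, known or untested is meant among the compounds shown, and "the series" means these compounds.

Measured compounds:
- compound 1, `CCCCC[Se]c1nc(NCc2ccc(SC)cc2)c2ccccc2n1`, 34700 nM
- compound 2, `CSc1ccc(CNc2nc([SeH])nc3ccccc23)cc1`, 410 nM
- compound 3, `Nc1nc([SeH])nc2ccccc12`, 80 nM

These three compounds were tested in an ADME assay on BEAS-2B cells (Homo sapiens) for cytotoxicity, read by MTT assay, with a stated time of 72 h; on this read-out higher numbers stand for weaker inhibition of growth and lower numbers for stronger inhibition of growth. Compound 3 gives the lowest number of the three, so it is the strongest inhibitor of growth here; compound 2 comes nearest, and compound 1 is furthest away. Compound 2 and compound 1 differ in one place, (pentyl in place of hydrogen on a selenium), and that change brought an 85-fold higher number from compound 2 to compound 1 (1.93 log units; beyond the scatter), a large step towards weaker inhibition of growth.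

Compound 4, `CCCCC[Se]c1nc(N)c2ccccc2n1`, has not yet been measured in this assay. It stands to compound 3 as compound 1 stands to compound 2: pentyl in place of hydrogen on a selenium. The place is described in the same words in both cases. How the core of compound 3 differs from that of compound 2 is not broken down here.

Since the same change is made on a different core, the size of the step is expected to be similar in direction, and compound 4 is estimated to show a 63-fold higher number from compound 3 to compound 4 (1.80 log units; beyond the scatter), a weakening of the kind seen in an 85-fold higher number from compound 2 to compound 1 (1.93 log units; beyond the scatter). Compound 4 is therefore expected to give about 5000 nM, within a range of 1000 nM to 30000 nM.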

Compound 4, concentration for 50% growth inhibition: 52300 nM
Beside the measured number, compound 4's estimate is 10-fold (1.02 log units) below it; measured number above the stated range.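

Placing pentyl on the selenium of compound 3 brought a 650-fold higher number from compound 3 to compound 4 (2.82 log units; beyond the scatter) in this assay, so growth inhibition again became weaker. Both cores therefore move in the same direction with this change, but the size of the step does not carry over unchanged: the same change on two cores in this assay, an 85-fold higher number (1.93 log units; beyond the scatter) from compound 2 to compound 1 and a 650-fold higher number (2.82 log units; beyond the scatter) from compound 3 to compound 4, 7.7-fold (0.89 log units) apart, beyond the scatter of two such steps

Among the compounds shown here, with only two pairs of compounds, this shows that the direction held on these two cores, but it does not explain why the steps differ in size or predict the step on any other core.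

The compounds shown leave open how a shorter chain such as ethyl or a longer chain such as octyl would behave on the selenium, so no link between chain length and growth inhibition can be drawn. They also leave open what a benzyl group, or a chain carrying an amine or a carboxylic acid, would do in place of pentyl.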